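A few compounds are considered here, and "the series" means these few. Any claim that something is new, unique, unknown or untested is made for them only; others in the source may bear on it.

The shared core carries, on its aromatic carbon two atoms from the ring nitrogen, a varying aryl group, and three such compounds have been measured in an assay for binding affinity to dual specificity mitogen-activated protein kinase kinase 4 (Homo sapiens), read by KINOMEscan, tested at 100 nM; a higher number here means a weaker effect of the compound at the concentration tested, a lower number a stronger effect. Compound 1 `CCCS(=O)(=O)Nc1ccc(F)c(C(=O)c2n[nH]c3ncc(-c4ccccc4F)cc23)c1F` gives 2%. Compound 2 `CCCS(=O)(=O)Nc1ccc(F)c(C(=O)c2n[nH]c3ncc(-c4cccc(N)c4)cc23)c1F` gives 1.6%, the lowest of the three numbers, though its step of a number 0.4 percentage points lower from compound 1 to compound 2 (within the scatter) lies within the scatter. Compound 3 `CCCS(=O)(=O)Nc1ccc(F)c(C(=O)c2n[nH]c3ncc(-c4cccc([N+](=O)[O-])c4)cc23)c1F` gives 15%; here the steps of a number 13 percentage points higher from compound 1 to compound 3 (beyond the scatter) and a number 13.4 percentage points higher from compound 2 to compound 3 (beyond the scatter) are beyond the scatter, so exchanging the amino group for nitro weakens binding modestly.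

The next compound, compound 4 `CCCS(=O)(=O)Nc1ccc(F)c(C(=O)c2n[nH]c3ncc(-c4ccc(S(C)(=O)=O)cc4)cc23)c1F`, differs from compound 2 by 4-(methylsulfonyl)phenyl in place of 3-aminophenyl on an aromatic carbon. Within the data shown here, no measured step involves a methylsulfonyl group, so the expectation rests on analogy: two of the three aryl groups tried gave numbers within the scatter of each other, and only the nitro group, a group without a hydrogen-bond donor, raised the number by a modest amount. The entering group likewise has no donor, so a modest rise is expected, estimated as a number 8.4 percentage points higher from compound 2 to compound 4 (within the scatter). Compound 4 is therefore expected to give about 10% in this assay, with a range from 2% to 30%.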

Compound 4, a percentage reported as activity, at one concentration (the size of the read-out at that concentration, not a potency): 1.5%
Compound 4: the middle estimate sits 8.5 percentage points above what was measured; measured number outside the range, below it.
By their numbers in this assay, from the lowest: compounds 4, 2 and 1 (each within the scatter of the next); then compound 3.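

In this assay, 4-(methylsulfonyl)phenyl in place of the earlier aryl groups gives a number 0.1 percentage points lower from compound 2 to compound 4 (within the scatter) and a number 0.5 percentage points lower from compound 1 to compound 4 (within the scatter) but also a number 13.5 percentage points lower from compound 3 to compound 4 (beyond the scatter), so this position accepts a sulfone-bearing aryl group as well as the amino and fluoro ones, and only compound 3 stands apart. Compound 4 has no hydrogen-bond donor on this aryl group yet stays level with compound 2, which does have one, so among these compounds the absence of a donor does not go with a higher number, and compound 3 is the only one that fits such a link. No measurement shown here explains why the nitro compound differs, and its group also sits elsewhere on the phenyl ring than the methylsulfonyl group does.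

As far as these compounds go, whether moving the methylsulfonyl group to the 3-position or the nitro group to the 4-position would change the number remains open. It is also unknown how a carboxylic acid or a morpholine on the phenyl ring would behave, or whether a small alkyl chain could replace the aryl group altogether.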